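Hydroxy in place of benzylamino: an expected cytotoxicity limit

The source may hold more compounds than are shown below. What is called first, only, known or untested is meant among the compounds shown, and "the series" means these compounds.

Measured so far in a functional assay on A549 cells (Homo sapiens) for cytotoxicity, read by MTT assay, with a stated time of 24 h; on this read-out lower numbers stand for stronger inhibition and higher numbers for weaker inhibition:
compound 1 `C=CC1=C(C(=O)NCc2ccccc2)C(c2ccc(OC)cc2)OC1` gives > 100000 nM.
compound 2 `C=CC1=C(C(=O)O)C(c2ccc(OC)cc2)OC1` gives > 100000 nM.
compound 3 `C=CC1=C(C(=O)NCc2ccccc2)C(c2ccc(Cl)c(Cl)c2)OC1` gives > 100000 nM.

Each of these three values is a limit of this assay and not a number. Compound 2 arises from compound 1 through (hydroxy in place of benzylamino on a carbonyl carbon), and the resulting step is a step that the two limits leave unreadable from compound 1 to compound 2. Compound 3 arises from compound 1 through (3,4-dichlorophenyl in place of 4-methoxyphenyl on a saturated ring carbon), and that step is a step that the two limits leave unreadable from compound 1 to compound 3; this is also how the core of compound 3 differs from the core of compound 1. Compound 4 `C=CC1=C(C(=O)O)C(c2ccc(Cl)c(Cl)c2)OC1` has not yet been measured in this assay. It differs from compound 3 by hydroxy in place of benzylamino on a carbonyl carbon, the same change as that from compound 1 to compound 2, made at a place described in the same words. For compound 4 the step from compound 3 is expected to be a step that the limit leaves unreadable from compound 3 to compound 4, which rests on the limit of > 100000 nM in this assay, at which 3 of the 3 values shown sit, and on a step that the two limits leave unreadable from compound 1 to compound 2. Compound 4 is therefore expected to give 150000 nM, with a likely range from 60000 nM to 500000 nM, most probably again reported only as a limit.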

Compound 4, half-maximal inhibitory concentration: > 100000 nM
Compound 4: a limit, no number (the forecaster's own chance of this, stated with the estimate: 85%); the middle value is on the limit's open side.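

In this assay compound 4 gives > 100000 nM as a limit of the assay and not a number. No step can be read from compound 3 to compound 4, since both values are limits. The compounds shown leave open whether any change to the shared core would give a measurable value, and how large any such step would be.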